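Bromo in Place of Fluoro on the Aromatic Ring

The source may report more compounds than this note shows. Statements on the series, on what has been measured and on what is new or still open speak of the compounds shown alone.

In a functional assay on NCI-H520 cells (Homo sapiens) (a lower number here means a stronger inhibitor of growth, a higher number a weaker inhibitor of growth), compound 1 `COc1cc2ncnc(Nc3ccc(CS(=O)(=O)/C=C/c4ccc(Cl)cc4Cl)cc3)c2cc1OC` gives 6000 nM.

Compound 2 `COc1cc2ncnc(Nc3ccc(CS(=O)(=O)/C=C/c4ccc(F)cc4)cc3)c2cc1OC` reads > 100000 nM, which is a limit of the assay and not a number.

Compound 3 `COc1cc2ncnc(Nc3ccc(CS(=O)(=O)/C=C/c4ccc(Br)cc4)cc3)c2cc1OC` differs from it by bromo in place of fluoro on an aromatic carbon.

Within the data shown here, only one measured step bears on this change, and it is large: an at least 16-fold higher number from compound 1 to compound 2 (1.22 log units; beyond the scatter). So swapping halogens on this ring can shift growth inhibition strongly.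

In this assay a lower number is therefore expected, with an estimated step of an at least 5.0-fold lower number from compound 2 to compound 3 (0.69 log units; beyond the scatter).

For compound 3 the expected value is 20000 nM, with an estimated range of 3000 nM to 100000 nM.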

Compound 3, concentration for 50% growth inhibition: 8000 nM
Compound 3: the middle estimate sits 2.5-fold (0.40 log units) above what was measured; the measured number falls inside the stated range.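

In this assay, bromo in place of fluoro on this aromatic carbon, para to a large group, restores measurable growth inhibition, with an at least 12-fold lower number from compound 2 to compound 3 (1.09 log units; beyond the scatter). Compound 2 gives only a limit of the assay, not a number: the limit of > 100000 nM in this assay, at which 1 of the 3 values shown sits. The change from 2,4-dichlorophenyl to 4-bromophenyl gives a 1.3-fold higher number from compound 1 to compound 3 (0.12 log units; within the scatter), so these two groups cannot be told apart here.

As far as these compounds go, what a methyl, methoxy or nitrile group on this carbon would give remains open. So does how a 4-chlorophenyl group would compare.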